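The source may hold more compounds than are shown below. What is called first, only, known or untested is meant among the compounds shown, and "the series" means these compounds.

Measured so far in a functional assay on MOLT-4 cells (Homo sapiens) for antiproliferative activity, read by MTT assay, with a stated time of 3 days; on this read-out higher numbers stand for weaker inhibition and lower numbers for stronger inhibition:

Compound 1 `CCCCCCCCC#Cc1cn(C/C=C\CN2C(=O)c3ccccc3C2=O)c(=O)[nH]c1=O` gives 36000 nM.
Compound 2 `CCCCCCCCC#Cc1cn(C/C=C/CN2C(=O)c3ccccc3C2=O)c(=O)[nH]c1=O` gives only a limit of the assay, > 250000 nM.
Compound 3 `CCCCCc1ccc(C#Cc2cn(C/C=C/CN3C(=O)c4ccccc4C3=O)c(=O)[nH]c2=O)cc1` gives 17000 nM.

Among the two plain numbers, compound 1 has the higher one, and compound 3 the lower, a gap beyond the scatter.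

Compound 4 `O=C1c2ccccc2C(=O)N1C/C=C\Cn1cc(C#CCCc2ccccc2)c(=O)[nH]c1=O` differs from compound 1 in one place: phenyl in place of hexyl on a saturated chain carbon, two bonds along the chain from a triple-bonded carbon. Read one bond further out, this is octyl becoming phenethyl at the triple bond.

Going by the values given here, two measured steps bear on this. The step of an at least 6.9-fold higher number from compound 1 to compound 2 (0.84 log units; beyond the scatter) shows that the geometry of the double bond matters; compound 4 keeps the configuration of compound 1. The step of an at least 14-fold lower number from compound 2 to compound 3 (1.16 log units; beyond the scatter) shows that an aromatic ring in place of a plain chain at the triple bond gave a much lower number. Compound 4 carries its ring two bonds further out, so a lower number is expected, of moderate size, a 2.4-fold lower number from compound 1 to compound 4 (0.38 log units; beyond the scatter).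

Compound 4 is therefore estimated at 15000 nM, with a range from 4000 nM to 60000 nM.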

Compound 4, half-maximal inhibitory concentration: 146000 nM
Compound 4: the middle estimate sits 9.7-fold (0.99 log units) below what was measured; measured number outside the range, above it.
By their numbers in this assay, from the lowest: compound 3; then compound 1; then compound 4. At a limit, above all of these: compound 2.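

In this assay the change from hexyl to phenyl, on a saturated chain carbon two bonds along the chain from a triple-bonded carbon, gives a 4.1-fold higher number from compound 1 to compound 4 (0.61 log units; beyond the scatter) and so weaker inhibition, with the double bond drawn the same way in both compounds. The earlier change of octyl to 4-pentylphenyl on a triple-bonded carbon gave an at least 14-fold lower number from compound 2 to compound 3 (1.16 log units; beyond the scatter) and so went the other way; an aromatic ring in the side chain therefore does not lower the number in every setting. Nothing measured here explains this difference between the two changes.

The compounds shown leave open whether the loss comes from removing the long chain or from adding the ring, which a compound with a pentyl group on the phenyl of compound 4 could begin to separate. They also leave open how a polar end group such as an amine or a carboxylic acid would fare at this place on the chain.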